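A few compounds are considered here, and "the series" means these few. Any claim that something is new, unique, unknown or untested is made for them only; others in the source may bear on it.

In a functional assay on MDA-MB-468 cells (Homo sapiens) for cytotoxicity, read by resazurin assay, with a stated time of 72 h (a lower number here means a stronger inhibitor, a higher number a weaker inhibitor), three compounds carry numbers or limits. Compound 1, `O=C(CCSC(=S)NCc1cccnc1)NCc1ccccc1`, reaches only the limit of the assay, > 100000 nM, and that limit is one of the values shown (the limit of > 100000 nM in this assay, at which 1 of the 3 values shown sits). Compound 2, `O=S(=O)(O)CCCSC(=S)NCc1cccnc1`, gives 11100 nM in this assay. Compound 3, `COc1ccc(-c2nnc(CCSC(=S)NCc3cccnc3)o2)cc1`, gives 5220 nM in this assay, which is the lowest of the two numbers; the nearest number is that of compound 2, and the gap between them lies beyond the usual scatter. Compound 4, `S=C(NCc1cccnc1)SCCc1nnc(-c2cccnc2)o1`, has not yet been measured in this assay. It differs from compound 3 in one place: pyridin-3-yl in place of 4-methoxyphenyl on an aromatic carbon of the five-membered aromatic ring. Among the compounds with values here, no measured pair shows the effect of such an exchange, so the size of the step can only be guessed. The expected step from compound 3 to compound 4 is a 1.3-fold higher number from compound 3 to compound 4 (0.13 log units; within the scatter), no larger than the scatter. Compound 4 is therefore estimated at 7000 nM in this assay, with a range from 2500 nM to 20000 nM.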

Compound 4, half-maximal inhibitory concentration: 3160 nM
Beside the measured number, compound 4's estimate is 2.2-fold (0.35 log units) above it; low and high end bracket the measured number.
By their numbers in this assay, from the lowest: compounds 4 and 3 (each within the scatter of the next); then compound 2. At a limit, above all of these: compound 1.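

In this assay, the exchange of 4-methoxyphenyl for pyridin-3-yl on an aromatic carbon of the five-membered aromatic ring gives a 1.7-fold lower number from compound 3 to compound 4 (0.22 log units; within the scatter). Within the data shown here, this is the first pair in the set that differs in one place, and it shows that a six-membered aromatic ring with 1 hetero atom can stand at this position in place of the carbon-only ring, with no change that can be told from the scatter. Nothing measured here offers a reason for this outcome.

The compounds shown leave open whether an unsubstituted phenyl or pyridin-4-yl at this position would give a number beyond the scatter of compound 3. They also leave open what an amine or a carboxylic acid on this aromatic ring, or a longer chain leading to the five-membered ring, would do.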